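Aryl swap on the saturated ring carbon: compound 4

The source may hold more compounds than are shown below. What is called first, only, known or untested is meant among the compounds shown, and "the series" means these compounds.

Compound 3 `COc1cc(N2C(N)=C(C#N)C(c3ccc(O)cc3)C3=C2CC(C)(C)CC3=O)cc(OC)c1OC` holds the highest of the three numbers in a functional assay on Ehrlich cells (Mus musculus) for cytotoxicity, tested at 50 ug/mL; a lower number here means a weaker effect, a higher number a stronger effect of the compound at the concentration tested: compound 3 gives 90%. Compound 2 `COc1ccccc1C1C(C#N)=C(N)N(c2cc(OC)c(OC)c(OC)c2)C2=C1C(=O)CC(C)(C)C2` gives 70%, and compound 1 `COc1cc(N2C(N)=C(C#N)C(c3c(O)ccc4ccccc34)C3=C2CC(C)(C)CC3=O)cc(OC)c1OC` gives 15%. Within the data shown here, both gaps to compound 3 lie beyond the scatter, so compound 3 is the most active compound measured so far.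

Compound 4 `COc1cc(N2C(N)=C(C#N)C(c3ccc(Cl)cc3Cl)C3=C2CC(C)(C)CC3=O)cc(OC)c1OC` differs from compound 3 at one place: 2,4-dichlorophenyl in place of 4-hydroxyphenyl on a saturated ring carbon. All three measured steps also exchange the aryl group on this saturated ring carbon, so all of them bear on the change. The step of a number 20 percentage points higher from compound 2 to compound 3 (beyond the scatter) was modest, whereas a number 75 percentage points higher from compound 1 to compound 3 (beyond the scatter) and a number 55 percentage points higher from compound 1 to compound 2 (beyond the scatter) were large, so this position can move the read-out across most of the scale. Among the measured compounds shown here, no measured compound carries a halogenated aryl here. The entering 2,4-dichlorophenyl has no hydrogen-bond donor or acceptor; the nearest measured analogue without a donor is compound 2, which gives 70%.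

A modest decrease from compound 3 is therefore expected, as a number 25 percentage points lower from compound 3 to compound 4 (beyond the scatter). Compound 4 is estimated at 65%, with an expected range from 30% to 90%.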

Compound 4, a percentage reported as activity, at one concentration (the size of the read-out at that concentration, not a potency): 95%
Estimate against measurement, compound 4: 30 percentage points below, outside the stated range (above it).
By their numbers in this assay, from the lowest: compound 1; then compound 2; then compounds 3 and 4 (each within the scatter of the next).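

In this assay, the step of a number 5 percentage points higher from compound 3 to compound 4 (within the scatter) shows that 2,4-dichlorophenyl on this saturated ring carbon can replace 4-hydroxyphenyl without a separable change in the read-out, so in this pair a high number does not depend on the hydroxyl group or on a hydrogen-bond donor or acceptor in the aryl group. The entering group also stands clear of the other two aryl groups in the steps of a number 25 percentage points higher from compound 2 to compound 4 (beyond the scatter) and a number 80 percentage points higher from compound 1 to compound 4 (beyond the scatter), so the presence of a hydroxyl does not order these compounds: compound 1 carries one and gives the lowest number, while compound 4 carries none and is level with compound 3. No evidence is at hand on the origin of these differences.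

Compound 3 and compound 4 cannot be separated by this single-concentration read-out, so any difference in potency between them remains unresolved. Also open, going by these compounds, is whether both chlorines are needed, which a 4-chlorophenyl group on the same carbon would address, and how a 4-carboxyphenyl or 4-aminophenyl group would read there.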